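The source may hold more compounds than are shown below. What is called first, only, known or untested is meant among the compounds shown, and "the series" means these compounds.

Measured so far in a functional assay on SMMC-7721 cells (Homo sapiens) for cytotoxicity, read by MTT assay, with a stated time of 24 h; a higher number here means a weaker inhibitor, a lower number a stronger inhibitor:

- compound 1 `N#CC1=C2C(=NC1=O)c1cccc3c(Sc4ccc(Br)cc4)ccc2c13`: 190 nM
- compound 2 `N#CC1=C2C(=NC1=O)c1cccc3c(Sc4ccc(N)cc4)ccc2c13`: 18 nM

Compound 2 gives the lowest number of the two; in this assay compound 2 sits an 11-fold lower number from compound 1 to compound 2 (1.02 log units; beyond the scatter) below compound 1, a gap beyond the scatter. For the measured compounds named here, only one step has been measured, and it is this change of the group on the aromatic carbon para to the large group, so the whole of what is known about the series rests on it.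

Compound 3 `CCC(C)(C)c1ccc(Sc2ccc3c4c(cccc24)C2=NC(=O)C(C#N)=C23)cc1` is the next member: 1,1-dimethylpropyl in place of amino on an aromatic carbon. Going by the values given here, no measured step covers the group that enters; what bears on it is only the step from compound 1 to compound 2, which shows that exchanging the substituent at this position moved the number by a large amount. The amino group that made compound 2 the lowest of the two leaves, and a group without hydrogen-bond donor or acceptor, as in compound 1, enters. A move back toward the number of compound 1 is therefore expected, an 8.3-fold higher number from compound 2 to compound 3 (0.92 log units; beyond the scatter), with wide uncertainty. Compound 3 is estimated at 150 nM, within 40 nM to 600 nM.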

Compound 3, half-maximal inhibitory concentration: 11900 nM
Compound 3: middle estimate off by 79-fold (1.90 log units), on the low side; the measured number lies above the stated range.
By their numbers in this assay, from the lowest: compound 2; then compound 1; then compound 3.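

In this assay the aromatic carbon para to a large group turns out to separate more than amino from everything else: besides a 660-fold higher number from compound 2 to compound 3 (2.82 log units; beyond the scatter), there is also a 63-fold higher number from compound 1 to compound 3 (1.80 log units; beyond the scatter), so 1,1-dimethylpropyl does not return the series to the level set by bromo. Removing the amino group therefore does not by itself fix the number, since the two compounds without it, compound 1 and compound 3, stand apart from each other beyond the scatter, and the three substituents now give three clearly separated levels, with compound 2 lowest and compound 3 highest. Nothing available on these compounds bears on why the 1,1-dimethylpropyl group gives so high a number.

Open, as far as these compounds go, is whether the low number of compound 2 belongs to amino alone or would also appear with a hydroxyl, a methoxy or a dimethylamino group at this place. Also open, from the compounds shown here alone, is where a shorter chain such as methyl or ethyl would fall relative to compound 1 and compound 3, and whether a chlorine would stay close to bromo.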